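Aryl versus alkyl at the biaryl position, cytotoxicity

The source may report more compounds than this note shows. Statements on the series, on what has been measured and on what is new or still open speak of the compounds shown alone.

Among the measured compounds shown here, compound 3 `CCC(CC)c1ccc2c(NCCCNCc3ccco3)ccnc2c1` gives 6760 nM in an ADME assay on HepG2 cells (Homo sapiens) for cytotoxicity, read by luminescence, CellTiter-Glo and ATP content, with a stated time of 72 h (on this read-out higher numbers stand for an effect only at larger amounts of compound and lower numbers for an effect already at smaller amounts), the highest of the three numbers measured so far; its nearest neighbour is compound 2 `CC(C)(C)c1ccc(-c2ccc3c(NCCCNCc4ccco4)ccnc3c2)cc1` with 3150 nM, and furthest away is compound 1 `COc1ccc(-c2ccc3c(NCCCNCc4cccc(OC)c4O)ccnc3c2)cc1` with 1600 nM. Compound 4 `COc1ccc(-c2ccc3c(NCCCNCc4ccco4)ccnc3c2)cc1` differs from compound 3 by 4-methoxyphenyl in place of pentan-3-yl on an aromatic carbon. For the measured compounds named here, the one measured step that bears on this is the exchange in the other direction, a substituted phenyl for pentan-3-yl, a 2.1-fold higher number from compound 2 to compound 3 (0.33 log units; beyond the scatter). Going by the values given here, compound 1 and compound 4 share the 4-methoxyphenyl group but differ elsewhere, so that pair gives no clean step; the values of compound 1 and compound 3 only show that the compound carrying 4-methoxyphenyl sits at the lower number. Putting a phenyl group back in place of pentan-3-yl is therefore expected to move the number down by a modest step in this assay. For compound 4 the estimate is 2700 nM, with a range of 1200 nM to 6000 nM. The expected step is a 2.5-fold lower number from compound 3 to compound 4 (0.40 log units; beyond the scatter).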

Compound 4, half-maximal effective concentration: 6000 nM
Compound 4: middle estimate off by 2.2-fold (0.35 log units), on the low side, and the stated range covers the measured number.
By their numbers in this assay, from the lowest: compounds 1, 2, 4 and 3 (each within the scatter of the next, the first and the last beyond it).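

In this assay, 4-methoxyphenyl in place of pentan-3-yl on the aromatic carbon gives a 1.1-fold lower number from compound 3 to compound 4 (0.05 log units; within the scatter) and so does not repeat a 2.1-fold higher number from compound 2 to compound 3 (0.33 log units; beyond the scatter) in size, which shows that an aryl group at this position does not by itself set the number. Methoxy in place of tert-butyl on the aryl group gives a 1.9-fold higher number from compound 2 to compound 4 (0.28 log units; within the scatter) and leaves compound 2 and compound 4 unseparated. Among the compounds shown here, with 4-methoxyphenyl held fixed, furan-2-yl in place of 2-hydroxy-3-methoxyphenyl gives a 3.8-fold higher number from compound 1 to compound 4 (0.57 log units; beyond the scatter) and is the only new step beyond the scatter, which places the clearest change in this set at the amine end rather than at the aryl position.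

From the compounds shown here alone, how an amine or a carboxylic acid on the aryl group would read remains open. The data give no reason for any of these steps.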